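The source may report more compounds than this note shows. Statements on the series, on what has been measured and on what is new or still open speak of the compounds shown alone.

In a functional assay on RBL-2H3 cells (Rattus norvegicus) for inhibition, read by neutral red uptake, with stated times of 30 min and 1 h (a lower number here means a stronger inhibitor, a higher number a weaker inhibitor), compound 1 `COc1ccc(CN(CCN(C)C)c2ccccc2)cc1` gives 143 nM, compound 2 `COc1ccc(CN(CCN(C)C)c2ccc(Cl)cc2)cc1` gives 18.1 nM and compound 3 `COc1ccc(CN(CCN(C)C)c2ccc(C)cc2)cc1` gives 55.3 nM. Compound 3 therefore holds the second highest of the three numbers, a middle place. Compound 4 `COc1ccc(CN(CCN(C)C)c2ccc(Cl)cn2)cc1` carries 5-chloropyridin-2-yl in place of the 4-methylphenyl of compound 3 on an amine nitrogen: 5-chloropyridin-2-yl in place of 4-methylphenyl on an amine nitrogen. Two kinds of measured step bear on this change. Swapping chloro for methyl is the reverse of a 3.1-fold higher number from compound 2 to compound 3 (0.49 log units; beyond the scatter), and chloro in place of hydrogen gave a 7.9-fold lower number from compound 1 to compound 2 (0.90 log units; beyond the scatter), more than a 2.6-fold lower number from compound 1 to compound 3 (0.41 log units; beyond the scatter) seen with methyl in place of hydrogen. Compound 4 keeps a chloro, which points towards the lower number of compound 2. For the measured compounds named here, no measured compound has a ring with a hetero atom, however, so the effect of that part of the change is untested and part of the gain may be lost. A modest step is therefore expected in this assay, estimated as a 2.2-fold lower number from compound 3 to compound 4 (0.34 log units; beyond the scatter). For compound 4 the expected value is 25 nM, with an estimated range from 7 nM to 85 nM.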

Compound 4, half-maximal inhibitory concentration in the RBL-2H3 assay: 10.6 nM
Beside the measured number, compound 4's estimate is 2.4-fold (0.37 log units) above it, within the range that was stated.
By their numbers in the RBL-2H3 assay, from the lowest: compounds 4 and 2 (each within the scatter of the next); then compound 3; then compound 1.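

In the RBL-2H3 assay, the 5-chloropyridin-2-yl group brings the first ring with a hetero atom, and its exchange for 4-chlorophenyl gives a 1.7-fold lower number from compound 2 to compound 4 (0.23 log units; within the scatter), so compound 2 and compound 4 cannot be told apart and the ring nitrogen shows no measurable loss at this amine nitrogen. The larger steps, a 5.2-fold lower number from compound 3 to compound 4 (0.72 log units; beyond the scatter) and a 13-fold lower number from compound 1 to compound 4 (1.13 log units; beyond the scatter), therefore put compound 4 level with the other chloro compound. In a physicochemical assay for lipophilicity (a lower number here means a more polar compound, a higher number a more lipophilic compound), compound 3 gives 4.43 and compound 4 gives 3.87. Compound 4 also pairs its lower number than compound 3 in the RBL-2H3 assay with lower lipophilicity: the measured partition coefficient of compound 3, 4.43, and of compound 4, 3.87, a number 0.56 log units lower (beyond the scatter)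

As far as these compounds go, it remains open how a pyridin-2-yl ring would read with hydrogen, methyl or trifluoromethyl in place of the chloro. Also open, from the compounds shown here alone, is how a longer chain would read in place of the saturated chain carrying the dimethylamino group.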